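Removing Two Chlorines From a Ring on the Sulfonamide Nitrogen

The compounds below may be only part of what the source reports. "The series", "measured", "known", "first", "only" and "open" are said of these compounds alone.

Of the compounds shown here, three built on one shared core have been tested in a functional assay on CCRF-CEM cells (Homo sapiens) for inhibition; on this read-out higher numbers stand for lower toxicity in this test and lower numbers for higher toxicity in this test. Compound 1 `O=C1c2ccccc2N(COCc2ccccc2)S(=O)(=O)N1Cc1ccccc1` gives 25000 nM. Compound 3 `O=C1c2ccccc2N(Cc2ccccc2)S(=O)(=O)N1Cc1ccccc1` gives 108000 nM. Compound 2 `O=S1(=O)N=C(OCc2ccccc2)c2ccccc2N1Cc1ccc(Cl)c(Cl)c1` gives 30500 nM, the second highest of the three numbers; it and compound 1 lie within the scatter of each other, while compound 3 stands beyond it. Within the data shown here, the only step between compounds that differ in one place is a 4.3-fold higher number from compound 1 to compound 3 (0.64 log units; beyond the scatter). Compound 4 `O=S1(=O)N=C(OCc2ccccc2)c2ccccc2N1Cc1ccccc1` has not yet been measured; it differs from compound 2 by phenyl in place of 3,4-dichlorophenyl on a saturated chain carbon bound to a sulfonamide nitrogen in a ring. Among the measured compounds shown here, no measured pair swaps a chlorinated ring for a plain one, so the step between compound 1 and compound 3, which sits at the same place but exchanges a different pair of groups, is only a loose guide to how far a group there can move the number. For compound 4 the expected change is a 1.3-fold higher number from compound 2 to compound 4 (0.12 log units; within the scatter), with no firm reason for either direction. The estimate for compound 4 in this assay is 40000 nM, expected to fall between 15000 nM and 110000 nM.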

Compound 4, half-maximal cytotoxic concentration: 22200 nM
Compound 4: the middle estimate sits 1.8-fold (0.26 log units) above what was measured, within the range that was stated.
By their numbers in this assay, from the lowest: compounds 4, 1 and 2 (each within the scatter of the next); then compound 3.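

In this assay, phenyl in place of 3,4-dichlorophenyl on a saturated chain carbon bound to a sulfonamide nitrogen in a ring gives a 1.4-fold lower number from compound 2 to compound 4 (0.14 log units; within the scatter), so the two chlorines make no difference that this test can tell apart on this core. The earlier exchange of benzyloxy for phenyl gave a 4.3-fold higher number from compound 1 to compound 3 (0.64 log units; beyond the scatter), so a swap of groups on a saturated chain carbon bound to a sulfonamide nitrogen can shift the number, but this one does not. No measurement here offers an explanation for the result.

On these data alone, what a single chlorine, a methoxy group or an amine on this ring would give remains open. So does whether removing the two chlorines would read the same on the core of compound 1.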